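The compounds below may be only part of what the source reports. "The series", "measured", "known", "first", "only" and "open" are said of these compounds alone.

Measured so far:
compound 1 `NCc1ccc(C(=O)Nc2ccncc2F)cc1-c1cccc(C(=O)OCC2CCCO2)c1` — 49 nM
compound 2 `COC(=O)c1cccc(NC(=O)c2cccc(-c3cc(C(=O)Nc4ccncc4F)ccc3CN)c2)c1F` — 8.8 nM

In an assay on cells for inhibition of Rho-associated protein kinase 2 (Homo sapiens), read by radiometric assay and 33P incorporation, in the presence of a further agent that is not named here (on this read-out lower numbers stand for stronger inhibition and higher numbers for weaker inhibition), compound 2 gives 8.8 nM, the lowest of the two numbers; compound 1 is the nearest, and the step of a 5.6-fold lower number from compound 1 to compound 2 (0.75 log units; beyond the scatter) is beyond the scatter, so compound 2 stands as the stronger of the two on this read-out.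

Compound 3 `NCc1ccc(C(=O)Nc2ccncc2F)cc1-c1cccc(C(=O)Nc2ccccc2)c1` follows from compound 2 by the change (phenyl in place of 2-fluoro-3-(methoxycarbonyl)phenyl on an amide-type nitrogen). The amide-type nitrogen linking to the aromatic ring is kept; what goes is the 2-fluoro-3-(methoxycarbonyl) substitution of that ring.

Among the measured compounds shown here, only one measured step bears on this. a 5.6-fold lower number from compound 1 to compound 2 (0.75 log units; beyond the scatter) shows that exchanging the (oxolan-2-yl)methoxy ester for the substituted anilide lowers the number by a modest but real amount. For the measured compounds named here, it does not separate the contribution of the anilide itself from that of its fluorine and methoxycarbonyl groups, so no step isolates the change now made. Compound 3 is expected to keep part of the gain of compound 2 over compound 1 but not all of it. The step is expected to be a 2.5-fold higher number from compound 2 to compound 3 (0.40 log units; beyond the scatter), toward a somewhat higher number. Compound 3 is therefore estimated at 22 nM, with a range from 7 nM to 70 nM.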

Compound 3, half-maximal inhibitory concentration: 31 nM
The estimate for compound 3 lay 1.4-fold (0.15 log units) below the measured number; the measured number falls inside the stated range.
By their numbers in this assay, from the lowest: compound 2; then compounds 3 and 1 (each within the scatter of the next).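

Working from this assay, removing the fluorine and methoxycarbonyl substitution from the ring on the amide-type nitrogen gives a 3.5-fold higher number from compound 2 to compound 3 (0.55 log units; beyond the scatter), so the number at this position depends on the 2-fluoro-3-(methoxycarbonyl)phenyl substitution and not only on the presence of an aromatic ring on that nitrogen. The unsubstituted anilide, by contrast, gives a 1.6-fold lower number from compound 1 to compound 3 (0.20 log units; within the scatter), a step that does not separate anilino from (oxolan-2-yl)methoxy on the carbonyl carbon, so replacing the ester with a plain anilide gives no measurable change on this read-out, and the clear advantage of compound 2 over compound 1 appears only with the substituted phenyl. No measurement available here accounts for this difference.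

The fluorine and the methoxycarbonyl group leave together in this step, so their separate contributions remain unresolved, and a 2-fluorophenyl or 3-(methoxycarbonyl)phenyl group on the same nitrogen would divide the step between them. Also open, on these data alone, is whether the methyl ester itself matters, which a carboxylic acid or a primary amide at that place on the ring would test.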